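Phenyl for phenethyl on the core: solubility notes

The compounds below may be only part of what the source reports. "The series", "measured", "known", "first", "only" and "open" are said of these compounds alone.

Of the compounds shown here, three have been measured in a physicochemical assay for solubility, with a stated time of 18 h, at pH 7.4; a higher number here means a more soluble compound, a lower number a less soluble compound. Compound 1 `COc1cccc(CNCCCNc2ccnc3cc(-c4ccccc4)ccc23)c1O` gives 32000 nM. Compound 2 `COc1ccc(F)cc1CNCCCNc1ccnc2cc(CCc3ccccc3)ccc12` gives 4200 nM in this assay. Compound 3 `COc1cccc(CNCCCNc2ccnc3cc(CCc4ccccc4)ccc23)c1O` gives 4200 nM in this assay.

Compound 3 and compound 1 differ in one place: phenyl in place of phenethyl on an aromatic carbon The step is a 7.6-fold higher number from compound 3 to compound 1 (0.88 log units; beyond the scatter). Compound 3 and compound 2 differ in the group on the chain: 5-fluoro-2-methoxyphenyl in place of 2-hydroxy-3-methoxyphenyl on a saturated chain carbon bound to an amine nitrogen The step there is no change at the digits printed from compound 2 to compound 3 (within the scatter). Compound 2 and compound 3 stand level, together at the lowest of the three numbers, with compound 1 furthest from both.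

Compound 4 `COc1ccc(F)cc1CNCCCNc1ccnc2cc(-c3ccccc3)ccc12` has not yet been measured in this assay. It differs from compound 2 thus: phenyl in place of phenethyl on an aromatic carbon The place is the same word for word as in the change from compound 3 to compound 1, so this is the same change carried onto the other core; how the two cores differ is given above for compound 3 and compound 2. Among the compounds with values here, the expectation rests on a 7.6-fold higher number from compound 3 to compound 1 (0.88 log units; beyond the scatter), the one earlier instance of this change, and on no change at the digits printed from compound 2 to compound 3 (within the scatter), which shows the two starting points level. The expected step is a 7.1-fold higher number from compound 2 to compound 4 (0.85 log units; beyond the scatter). Within the data shown here, compound 4 is expected at 30000 nM, in a range from 12000 nM to 70000 nM, with the single precedent leaving the range wide.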

Compound 4, solubility: 32000 nM
Compound 4: the middle estimate sits 1.1-fold (0.03 log units) below what was measured; the range from low to high includes it.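

In this assay, the change from phenethyl to phenyl on an aromatic carbon gives a 7.6-fold higher number from compound 2 to compound 4 (0.88 log units; beyond the scatter) and, on the other starting point, a 7.6-fold higher number from compound 3 to compound 1 (0.88 log units; beyond the scatter) so the two steps read the same at the digits printed and the change carries across both compounds of the phenethyl pair without loss of size. The two chain groups stay level after the change, with 5-fluoro-2-methoxyphenyl in place of 2-hydroxy-3-methoxyphenyl giving no change at the digits printed from compound 1 to compound 4 (within the scatter) just as the reverse exchange on the phenethyl compounds gave no change at the digits printed from compound 2 to compound 3 (within the scatter) and so in these four compounds the chain group and the group on the core read as independent of each other. These are only two instances, resting on two chain groups that were level from the start, so they do not show that the step holds for any other group on the chain, and nothing at hand bears on why the step has this size.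

Still open, as far as these compounds go, is how benzyl in the same place would read against phenyl and phenethyl, and whether 3-phenylpropyl, a longer chain than phenethyl, would continue the same run. Also open is whether the step survives with a carboxylic acid or a dimethylamino group on the phenyl, since every group on an aromatic carbon shown here is plain carbon.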